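The compounds below may be only part of what the source reports. "The series", "measured", "known", "first", "only" and "open" are said of these compounds alone.

Two compounds of the series carry numbers in a functional assay on NCI-H460 cells (Homo sapiens) for inhibition, read by MTT assay, with a stated time of 72 h; on this read-out lower numbers stand for stronger inhibition and higher numbers for weaker inhibition. Compound 1 `COc1cc2c(Oc3ccc(NC(=O)c4nn(-c5ccccc5OC(F)(F)F)c(=O)cc4C)cc3F)ccnc2cc1OCCCN1CCN(C)CC1` gives 260 nM in this assay. Compound 2 `COc1cc2c(Oc3ccc(NC(=O)c4nn(-c5cccc(F)c5)c(=O)cc4C)cc3F)ccnc2cc1OCCCN1CCCCC1` gives 360 nM in this assay, the higher of the two numbers, with compound 1 inside the scatter of it. Compound 3 `COc1cc2c(Oc3ccc(NC(=O)c4nn(-c5cccc(F)c5)c(=O)cc4C)cc3F)ccnc2cc1OCCCN1CCN(C)CC1` is not yet measured; it differs from compound 2 by 4-methylpiperazin-1-yl in place of piperidin-1-yl on a saturated chain carbon, three bonds along the chain from an oxygen on an aromatic ring. For the measured compounds named here, no step between measured compounds covers this change, and compound 1 carries the entering group on a different aryl, so it gives no direct reading. The step from compound 2 to compound 3 is expected to stay within the scatter, a 1.2-fold lower number from compound 2 to compound 3 (0.08 log units; within the scatter). Compound 3 is therefore estimated at 300 nM, within 120 nM to 750 nM.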

Compound 3, half-maximal inhibitory concentration: 260 nM
Compound 3: the middle estimate sits 1.2-fold (0.06 log units) above what was measured; measured number inside the range.
By their numbers in this assay, from the lowest: compounds 1, 3 and 2 (each within the scatter of the next).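

In this assay the exchange of piperidin-1-yl for 4-methylpiperazin-1-yl on the saturated chain carbon now has a direct reading, a 1.4-fold lower number from compound 2 to compound 3 (0.14 log units; within the scatter), so these two rings are not told apart here. With 4-methylpiperazin-1-yl held fixed, the exchange on the aromatic nitrogen also gets its first reading, no change at the digits printed from compound 1 to compound 3 (within the scatter), so these two aryl groups are not told apart either. No supporting data bear on these readings.

Open, as far as these compounds go, is whether morpholin-4-yl, dimethylamino or a longer chain would stay within the scatter. Open too, from the compounds shown here alone, is how unsubstituted phenyl would read on the aromatic nitrogen.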